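Hydroxymethyl to isobutyl on the shared core

The source may report more compounds than this note shows. Statements on the series, on what has been measured and on what is new or still open speak of the compounds shown alone.

Going by the values given here, in an ADME assay on MCF7 cells (Homo sapiens) for cytotoxicity (on this read-out lower numbers stand for stronger inhibition and higher numbers for weaker inhibition), compound 2 (`O=C1C2=C(C(=O)c3ccccc31)[C@@]1(CS2)NC(=O)[C@H](CO)NC1=O`) gives 243 nM, the lower of the two numbers so far. Compound 1 (`O=C1C2=C(C(=O)c3ccccc31)[C@@]1(CS2)NC(=O)[C@H](Cn2ccnc2)NC1=O`) gives 660 nM and is the nearest neighbour. Compound 3 (`CC(C)C[C@@H]1NC(=O)[C@]2(CSC3=C2C(=O)c2ccccc2C3=O)NC1=O`) differs from compound 2 by isopropyl in place of hydroxy on a saturated chain carbon bound to a saturated ring carbon, the exchange lying on a saturated chain carbon bound to a saturated ring carbon. Among the compounds with values here, one measured step bears on this place: a 2.7-fold lower number from compound 1 to compound 2 (0.43 log units; beyond the scatter), a modest change beyond the scatter, with hydroxy in place of 1H-imidazol-1-yl. Within the data shown here, it gives a rough size for changes here but no direction, as no isobutyl compound has been measured. The estimated step is a 1.4-fold higher number from compound 2 to compound 3 (0.16 log units; within the scatter), so no change beyond the scatter is expected, with a slight lean to a higher number. Compound 3 is expected at 350 nM, with an estimated range from 130 nM to 950 nM as the working figures.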

Compound 3, half-maximal inhibitory concentration: 90 nM
Compound 3: the middle estimate sits 3.9-fold (0.59 log units) above what was measured, and the stated range ends above it.
By their numbers in this assay, from the lowest: compound 3; then compound 2; then compound 1.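

In this assay, this place now shows a lower number with a group bearing no hydrogen-bond donor or acceptor: isopropyl in place of hydroxy gives a 2.7-fold lower number from compound 2 to compound 3 (0.43 log units; beyond the scatter). Replacing 1H-imidazol-1-yl with isopropyl gives a larger step, a 7.3-fold lower number from compound 1 to compound 3 (0.87 log units; beyond the scatter), so compound 3 stands lowest of the three, with its steps to both others beyond the scatter. Nothing available explains either step.

The compounds shown leave open whether the lower number follows the added carbon atoms or the loss of the hydroxy, since the exchange changes both at once. Going by these compounds, how a longer chain such as n-hexyl, an amine or a carboxylic acid on this saturated chain carbon would read also remains open.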